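Chloro on the benzyl groups: cytotoxicity working notes

The compounds below may be only part of what the source reports. "The series", "measured", "known", "first", "only" and "open" are said of these compounds alone.

Measured so far in a functional assay on CCRF-CEM cells (Homo sapiens) for inhibition; on this read-out higher numbers stand for lower toxicity in this test and lower numbers for higher toxicity in this test:
- compound 1 `O=C1c2ccccc2N(Cc2ccccc2)S(=O)(=O)N1Cc1ccc(Cl)cc1`: 27800 nM
- compound 2 `O=C1c2ccccc2N(Cc2ccccc2)S(=O)(=O)N1Cc1ccccc1`: 108000 nM
- compound 3 `O=C1c2ccccc2N(Cc2ccccc2)S(=O)(=O)N1Cc1ccccc1Cl`: reported only as a limit of this assay, > 250000 nM

Compound 1 holds the lowest of the two numbers shown; the nearest is compound 2, with a 3.9-fold higher number from compound 1 to compound 2 (0.59 log units; beyond the scatter). The move to compound 3 reads an at least 8.9-fold higher number from compound 1 to compound 3 (0.95 log units; beyond the scatter), and from compound 2 to compound 3 an at least 2.3-fold higher number from compound 2 to compound 3 (0.36 log units; beyond the scatter); the value of compound 3 sits at the limit of > 250000 nM in this assay, at which 1 of the 3 values shown sits.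

Compound 4 `O=C1c2ccccc2N(Cc2ccc(Cl)cc2)S(=O)(=O)N1Cc1ccc(Cl)cc1` differs from compound 1 by chloro in place of hydrogen on an aromatic carbon. Within the data shown here, two measured steps bear on this: removing the chloro gave a 3.9-fold higher number from compound 1 to compound 2 (0.59 log units; beyond the scatter), so the chloro in compound 1 goes with the lower number; adding a chloro elsewhere, in the ring of compound 3, gave an at least 2.3-fold higher number from compound 2 to compound 3 (0.36 log units; beyond the scatter). The new chloro sits para to a large group, as in compound 1, so a modest step downward in this assay is expected, a 1.9-fold lower number from compound 1 to compound 4 (0.27 log units; within the scatter). Compound 4 is therefore estimated at 15000 nM, within 6000 nM to 45000 nM.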

Compound 4, half-maximal cytotoxic concentration: 35800 nM
The estimate for compound 4 lay 2.4-fold (0.38 log units) below the measured number; measured number inside the range.
By their numbers in this assay, from the lowest: compounds 1 and 4 (each within the scatter of the next); then compound 2. At a limit, above all of these: compound 3.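

In this assay, turning the unsubstituted benzyl group of compound 1 into 4-chlorobenzyl gives a 1.3-fold higher number from compound 1 to compound 4 (0.11 log units; within the scatter), so at this position the added chloro leaves no reading beyond the scatter. The 4-chlorobenzyl group already present in compound 1 behaves differently: replacing its chloro with hydrogen gives a 3.9-fold higher number from compound 1 to compound 2 (0.59 log units; beyond the scatter), so the two chloro sites of the series do not read alike on these compounds. Whether this chloro step truly differs from the one leading to compound 3 stays unsettled: the same change on two cores in this assay, an at least 2.3-fold higher number (0.36 log units; beyond the scatter) from compound 2 to compound 3 and a 1.3-fold higher number (0.11 log units; within the scatter) from compound 1 to compound 4; the limit leaves it open whether they differ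

Still open, on these data alone, is whether 4-chlorobenzyl at this position would also read within the scatter with no chloro on the other benzyl group, as a single change from compound 2. Also open, as far as these compounds go, is whether a carboxylic acid or an amine on this ring would move the number where chloro does not.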